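This account rests on a few compounds, and the source may have more. Where it says the series, first, only, none or still open, it means among the compounds named here.

Measured in a functional assay on HeLa cells (Homo sapiens) for cytotoxicity, read by MTT assay; a lower number here means a stronger inhibitor, a higher number a weaker inhibitor:
- Compound 1 `CC(C)=CC[C@@H](OC[C@H](C)O)C1=CC(=O)c2c(O)ccc(O)c2C1=O`: 40300 nM
- Compound 2 `CCCCCCC(C)(O)CC(=O)O[C@H](CC=C(C)C)C1=CC(=O)c2c(O)ccc(O)c2C1=O`: > 100000 nM

Compound 2 stands at a limit of the assay, > 100000 nM, and this is not a number. Compound 3 `CC(C)=CC[C@@H](OC(=O)C1CCOC1)C1=CC(=O)c2c(O)ccc(O)c2C1=O` has oxolan-3-yl in place of 2-hydroxy-2-methyloctyl on a carbonyl carbon. No measured pair sizes this change, so the expectation leans on compound 1 at 40300 nM. In this assay, a moderate move towards stronger inhibition is expected, though its starting point is only a limit. The expected step is an at least 3.3-fold lower number from compound 2 to compound 3 (0.52 log units; beyond the scatter). For compound 3 the estimated value is 30000 nM, with an expected range of 7000 nM to 100000 nM.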

Compound 3, half-maximal inhibitory concentration: 73500 nM
Compound 3: the middle estimate sits 2.5-fold (0.39 log units) below what was measured; measured number inside the range.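

In this assay compound 2 gives only a limit, so exchanging 2-hydroxy-2-methyloctyl for oxolan-3-yl on the carbonyl carbon can be sized only as a floor, an at least 1.3-fold lower number from compound 2 to compound 3 (0.13 log units; that floor lies within the scatter). Putting (oxolan-3-yl)carbonyl in place of 2-hydroxypropyl on the oxygen gives a 1.8-fold higher number from compound 1 to compound 3 (0.26 log units; within the scatter), so these two groups cannot be told apart here. The true size of the first step remains unknown: the limit of > 100000 nM in this assay, at which 1 of the 3 values shown sits.

Open, on these data alone, is how a butyl chain or an amine on the carbonyl carbon would read, and whether any group there moves the number beyond the scatter from compound 1.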